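This account rests on a few compounds, and the source may have more. Where it says the series, first, only, none or still open, it means among the compounds named here.

Measured so far in a functional assay on SK-MEL-2 cells (Homo sapiens) for cytotoxicity; on this read-out lower numbers stand for stronger inhibition and higher numbers for weaker inhibition:
- compound 1 `Oc1nc(-c2ccccc2)cc2ccccc12`: 2570 nM
- compound 2 `COc1ccc(-c2cc3cc(C)ccc3c(N3CCN(C)CC3)n2)cc1`: 3710 nM

Among the compounds with values here, these are the only two numbers. Compound 2 at 3710 nM lies within the usual scatter of compound 1 at 2570 nM, so the two cannot be ranked on this read-out.

The next compound to be tested is compound 3 `Cc1ccc2c(N3CCN(C)CC3)nc(-c3ccccc3C)cc2c1`. Against compound 2 it carries one change: 2-methylphenyl in place of 4-methoxyphenyl on an aromatic carbon. In words, 2-methylphenyl stands in place of 4-methoxyphenyl on an aromatic carbon, next to the ring nitrogen and meta to a 4-methylpiperazin-1-yl group. The rest of the structure stays as it is.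

Within the data shown here, no measured pair differs in one place only, so the data give no direct measure of what such a change does in this assay. With no evidence for either direction, no step beyond the scatter is expected. The estimated move is small, a 1.1-fold higher number from compound 2 to compound 3 (0.03 log units; within the scatter), and it stays within the scatter.

For compound 3 the estimated value is 4000 nM, with an expected range of 1500 nM to 11000 nM.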

Compound 3, half-maximal inhibitory concentration: 3380 nM
Beside the measured number, compound 3's estimate is 1.2-fold (0.07 log units) above it, within the range that was stated.
By their numbers in this assay, from the lowest: compounds 1, 3 and 2 (each within the scatter of the next).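

In this assay, within the data shown here, the replacement of 4-methoxyphenyl by 2-methylphenyl, on the aromatic carbon next to the ring nitrogen, gives a 1.1-fold lower number from compound 2 to compound 3 (0.04 log units; within the scatter) and is the first step between compounds that differ in one place only. The two aryl groups differ in their substituent and in where it sits, and the leaving group carries an oxygen and a hydrogen-bond acceptor while the entering group carries neither, yet this read-out does not separate compound 2 from compound 3. At this position, then, this one exchange leaves the cytotoxicity number within the scatter, which says nothing yet about other groups there. No measurement at hand accounts for this result.

A single step changes the substituent and its place on the phenyl ring together, so the two contributions cannot be told apart, and 2-methoxyphenyl or 4-methylphenyl would be needed to separate them. As far as these compounds go, whether this position tolerates every group equally also stays open, for instance a phenyl ring bearing a primary amine or a carboxylic acid, or a longer chain in place of the aryl group.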